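Chloro for fluoro on the aryl of compound 2

The source may report more compounds than this note shows. Statements on the series, on what has been measured and on what is new or still open speak of the compounds shown alone.

Three compounds of the series carry numbers. Compound 1 `Fc1ccc(C2=NN(C3=NC(c4ccccc4)CS3)C(c3cccc4ccccc34)C2)cc1` gives 22700 nM in a functional assay on BGC-823 cells (Homo sapiens) for inhibition, read by CCK-8 assay, with a stated time of 48 h; a lower number here means a stronger inhibitor, a higher number a weaker inhibitor. Compound 2 `Fc1ccc(C2=NN(C3=NC(c4ccccc4)CS3)C(c3ccc4ccccc4c3)C2)cc1` gives 17300 nM in this assay, and compound 3 `O=C1CSC(N2N=C(c3ccc(F)cc3)CC2c2ccc3ccccc3c2)=N1` gives 14900 nM in this assay. Compound 2 holds the second highest of the three numbers; its nearest neighbour is compound 3 and its furthest is compound 1, and both gaps lie within the scatter. The two measured steps, a 1.3-fold lower number from compound 1 to compound 2 (0.12 log units; within the scatter) and a 1.2-fold lower number from compound 2 to compound 3 (0.06 log units; within the scatter), are both within the scatter.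

Compound 4 `Clc1ccc(C2=NN(C3=NC(c4ccccc4)CS3)C(c3ccc4ccccc4c3)C2)cc1` differs from compound 2 by chloro in place of fluoro on an aromatic carbon. Neither measured step touches the 4-fluorophenyl: one exchanges the naphthyl on a saturated ring carbon, the other the group on the amine nitrogen in a ring. Within the data shown here, no measured step therefore bears directly on this change, and the two that exist were both within the scatter. The expected step from compound 2 to compound 4 in this assay is none beyond the scatter, a 1.2-fold lower number from compound 2 to compound 4 (0.06 log units; within the scatter). Compound 4 is accordingly estimated at 15000 nM, with a range from 6000 nM to 40000 nM.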

Compound 4, half-maximal inhibitory concentration: 14600 nM
Compound 4: middle estimate off by 1.0-fold (0.01 log units), on the high side, and the stated range covers the measured number.
By their numbers in this assay, from the lowest: compounds 4, 3, 2 and 1 (each within the scatter of the next).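

Among these compounds, the step at the 4-fluorophenyl is the first direct reading at this position: in this assay, 4-chlorophenyl in place of 4-fluorophenyl gives a 1.2-fold lower number from compound 2 to compound 4 (0.07 log units; within the scatter) and so stays within the scatter. With the naphthyl exchange and the exchange of the group on the amine nitrogen in a ring, this halogen exchange on an aromatic carbon, para to a large group, is a third single change that leaves the number within the scatter. No measurement at hand speaks to why the two halogens read alike.

Going by these compounds, whether a non-halogen group here, such as methoxy, an amine or a carboxylic acid, would give a step beyond the scatter remains open. Also open, on these data alone, is whether chloro for fluoro reads the same on the cores of compound 1 and compound 3.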